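Replacing the dichlorophenyl amide with a furan ring

The compounds below may be only part of what the source reports. "The series", "measured", "known", "first", "only" and "open" are said of these compounds alone.

Measured compounds:
compound 1, `O=C(Nc1c(C(O)(C(F)(F)F)C(F)(F)F)ccc2ccccc12)c1ccc(Br)cc1`, 47 nM
compound 2, `O=C(Nc1c(C(O)(C(F)(F)F)C(F)(F)F)ccc2ccccc12)c1ccc(I)cc1`, 154 nM
compound 3, `O=C(Nc1c(C(O)(C(F)(F)F)C(F)(F)F)ccc2ccccc12)c1cc(Cl)cc(Cl)c1`, 306 nM

All three compounds share one core and differ only in the aryl group on the carbonyl carbon, and all were tested in an assay on LtK cells with ATP-sensitive inward rectifier potassium channel 11 (Homo sapiens) as the target; a higher number here means that more compound is needed for the effect, a lower number that less compound is needed. Compound 3 shows the highest of the three numbers: its nearest neighbour is compound 2, and the difference between them, a 2.0-fold higher number from compound 2 to compound 3 (0.30 log units; within the scatter), stays within the scatter, while the gap to compound 1, a 6.5-fold higher number from compound 1 to compound 3 (0.81 log units; beyond the scatter), lies beyond it. The remaining step, a 3.3-fold higher number from compound 1 to compound 2 (0.52 log units; beyond the scatter), is likewise modest.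

Compound 4, `O=C(Nc1c(C(O)(C(F)(F)F)C(F)(F)F)ccc2ccccc12)c1ccco1`, carries the change (furan-2-yl in place of 3,5-dichlorophenyl on a carbonyl carbon). For the measured compounds named here, no measured pair swaps a six-membered carbon ring for a five-membered ring with a hetero atom, so the only guidance is that changes of the aryl group so far have moved the number by modest amounts and mostly upward away from compound 1. On that basis compound 4 is expected to give a number close to or somewhat above that of compound 3, an estimated step of a 2.0-fold higher number from compound 3 to compound 4 (0.29 log units; within the scatter), with wide uncertainty. The estimate for compound 4 is therefore 600 nM, within a range of 150 nM to 2500 nM.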

Compound 4, half-maximal effective concentration: 9 nM
Compound 4: the middle estimate sits 67-fold (1.82 log units) above what was measured, and the stated range ends above it.
By their numbers in this assay, from the lowest: compound 4; then compound 1; then compounds 2 and 3 (each within the scatter of the next).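

In this assay, for the compounds shown here, the aryl group on the carbonyl carbon can move the number much further, and in the opposite direction, than the earlier compounds suggested: furan-2-yl in place of 3,5-dichlorophenyl gives a 34-fold lower number from compound 3 to compound 4 (1.53 log units; beyond the scatter), and furan-2-yl in place of 4-iodophenyl gives a 17-fold lower number from compound 2 to compound 4 (1.23 log units; beyond the scatter). The furan-2-yl group also improves on the best of the earlier aryl groups, 4-bromophenyl, with a 5.2-fold lower number from compound 1 to compound 4 (0.72 log units; beyond the scatter), so compound 4 stands beyond the scatter from all three other compounds. Compounds 1, 2 and 3 all carry six-membered carbon rings and differ from one another by modest steps at most, whereas compound 4 shows that a smaller five-membered aromatic ring with one hetero atom and one hydrogen-bond acceptor is not merely accepted at this position but gives the lowest number of the four.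

Nothing available explains this drop in the number. Going by these compounds, it remains open whether the ring oxygen, the smaller ring or the absence of halogen matters most, a question that thiophen-2-yl, unsubstituted phenyl or a bromofuranyl group on the same carbonyl carbon could help to separate.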